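This account rests on a few compounds, and the source may have more. Where it says the series, first, only, none or still open, it means among the compounds named here.

Compound 1 `CC(C)Cn1ccc(N2CCC(c3ccccc3)CC2)c(C#N)c1=O` gives 282 nM in a functional assay on CHO cells for positive allosteric modulation of metabotropic glutamate receptor 2 (Homo sapiens), with a stated time of 30 min; a higher number here means that more compound is needed for the effect, a lower number that less compound is needed.
Compound 2 `N#Cc1c(N2CCC(c3ccccc3)CC2)ccn(CC2CC2)c1=O` gives 151 nM in this assay.
Compound 3 `N#Cc1c(N2CCC(c3ccc(F)cc3)CC2)ccn(CC2CC2)c1=O` gives 89 nM in this assay.

Compound 2 stands second highest of these three numbers, and both steps that touch it, a 1.9-fold lower number from compound 1 to compound 2 (0.27 log units; within the scatter) and a 1.7-fold lower number from compound 2 to compound 3 (0.23 log units; within the scatter), fall within the scatter, so no order among the three is established. Compound 4 `N#Cc1c(N2CCC(c3cccc(C(F)(F)F)c3)CC2)ccn(CC2CC2)c1=O` differs from compound 2 in one place: trifluoromethyl in place of hydrogen on an aromatic carbon. Within the data shown here, the only measured step on that same ring is a 1.7-fold lower number from compound 2 to compound 3 (0.23 log units; within the scatter), which was small; a 1.9-fold lower number from compound 1 to compound 2 (0.27 log units; within the scatter) concerned the chain instead and was equally small. Among the measured compounds shown here, no measured step adds a trifluoromethyl anywhere, so the step is expected to be a 1.2-fold lower number from compound 2 to compound 4 (0.07 log units; within the scatter), not beyond the scatter. Compound 4 is therefore estimated at 130 nM, with a range from 40 nM to 400 nM.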

Compound 4, half-maximal effective concentration: 46 nM
Compound 4: the middle estimate sits 2.8-fold (0.45 log units) above what was measured; the measured number falls inside the stated range.
By their numbers in this assay, from the lowest: compounds 4, 3, 2 and 1 (each within the scatter of the next, the first and the last beyond it).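

In this assay, trifluoromethyl in place of hydrogen gives a 3.3-fold lower number from compound 2 to compound 4 (0.52 log units; beyond the scatter), the first single change among these compounds to go beyond the scatter. This shows that the aromatic ring carrying the new group can respond to a change at a carbon meta to a large group, although the fluoro step on this ring stayed within the scatter. Nothing measured here gives a reason for the size of this step.

On these data alone, it remains open whether a methyl, a methoxy or a chlorine on that same carbon would give a similar step. As far as these compounds go, it also remains open whether trifluoromethyl would do so on another carbon of that ring.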